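The source may report more compounds than this note shows. Statements on the series, on what has been measured and on what is new or still open speak of the compounds shown alone.

Measured so far:
compound 1 `O=C(CCl)Nc1ccc(Cn2nc(-c3ccc(Oc4ccccc4)cc3)cc2CO)cc1` — 400 nM
compound 2 `C=CC(=O)Nc1ccc(Cn2nc(-c3ccc(Oc4ccccc4)cc3)cc2C(=O)OCC)cc1` — 10900 nM
compound 3 `C/C=C/C(=O)Nc1ccc(Cn2nc(-c3ccc(Oc4ccccc4)cc3)cc2C(=O)OCC)cc1` — 52500 nM

All three numbers come from a functional assay on JeKo-1 cells (Homo sapiens) for inhibition, read by luminescence and CellTiter-Glo, with a stated time of 72 h; a lower number here means a stronger inhibitor, a higher number a weaker inhibitor. Compound 2 stands second highest of the three. Among the measured compounds shown here, its nearest neighbour is compound 3; the one measured single-point step is a 4.8-fold higher number from compound 2 to compound 3 (0.68 log units; beyond the scatter), a change confined to the acyl group of the amide. The furthest is compound 1, whose value of 400 nM lies well below, but compound 1 differs from compound 2 in two places at once, so that gap is not a single step.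

Compound 4 `C=CC(=O)Nc1ccc(Cn2nc(-c3ccc(Oc4ccccc4)cc3)cc2CO)cc1` is not yet measured. It differs from compound 2 as follows: hydroxymethyl in place of ethoxycarbonyl on an aromatic carbon. For the measured compounds named here, no measured step isolates this change. The only bearing comes from the comparison of compound 1 with compound 2, and that pair also carries the acyl-group change; the step from compound 2 to compound 3 shows that the acyl group alone can move the number modestly, so not all of the gap to compound 1 can be credited to the hydroxymethyl. A lower number is nonetheless expected for compound 4, by an estimated 5.5-fold lower number from compound 2 to compound 4 (0.74 log units; beyond the scatter). The estimate for compound 4 is 2000 nM, within a range of 400 nM to 9000 nM.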

Compound 4, half-maximal inhibitory concentration: 8000 nM
Compound 4: middle estimate off by 4.0-fold (0.60 log units), on the low side; the measured number falls inside the stated range.
By their numbers in this assay, from the lowest: compound 1; then compounds 4 and 2 (each within the scatter of the next); then compound 3.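

In this assay, the exchange of ethoxycarbonyl for hydroxymethyl on this aromatic carbon of the five-membered ring, read with the vinyl amide held constant, gives a 1.4-fold lower number from compound 2 to compound 4 (0.13 log units; within the scatter) and so leaves no change that can be told from the scatter in this pair. With hydroxymethyl held constant, vinyl in place of chloromethyl on the carbonyl carbon gives a 20-fold higher number from compound 1 to compound 4 (1.30 log units; beyond the scatter) as a large step, so the gap between compound 1 and the vinyl amides sits with the acyl group in this comparison and not with the group on the aromatic carbon. Nothing at hand explains either step.

Open, from the compounds shown here alone, is whether this aromatic carbon stays as tolerant when the chloromethyl amide is in place, since the present reading rests on one pair carrying the vinyl amide, and whether a carboxylic acid or an aminomethyl group there would fit the same picture. Also open, going by these compounds, is how a bromomethyl group or a longer chain on the carbonyl carbon would compare with the chloromethyl group of compound 1.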